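This account rests on a few compounds, and the source may have more. Where it says the series, first, only, none or still open, it means among the compounds named here.

Measured so far in an ADME assay on the whole organism (serum) for pharmacokinetics, with Mus musculus as the target; a lower number here means that the compound disappears faster, a higher number that the compound lasts longer:
- compound 1 `CN(C)CCCOc1ccc(NC(=O)COc2ccc(Cl)cc2C(=O)c2ccccc2)cc1`: < 0.25 h, a limit of the assay and not a number
- compound 2 `Cc1ccccc1CNC(=O)COc1ccc(Cl)cc1C(=O)c1ccccc1`: 2.8 h

Within the data shown here, compound 2 holds the only actual number in this assay, 2.8 h. The other result, for compound 1, is a limit.

Compound 3 `O=C(COc1ccc(Cl)cc1C(=O)c1ccccc1)c1cc2ccccc2[nH]1` has not yet been measured. It differs from compound 2 as follows: 1H-indol-2-yl in place of (2-methylbenzyl)amino on a carbonyl carbon. In words, 1H-indol-2-yl stands in place of (2-methylbenzyl)amino on a carbonyl carbon.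

Among the measured compounds shown here, no measured pair shows this change, so the expectation rests on compound 2 at 2.8 h and carries wide uncertainty. A small shortening is expected, about the size of the usual scatter: a 1.9-fold lower number from compound 2 to compound 3 (0.27 log units; within the scatter). For compound 3 the estimated half-life is 1.5 h, with an expected range of 0.4 h to 5 h.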

Compound 3, half-life: < 0.25 h
Compound 3 gave a limit, no number (the forecaster's own chance of this, stated with the estimate: 15%); middle value at least 6.0-fold (0.77 log units) from the limit.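

In this assay, 1H-indol-2-yl in place of (2-methylbenzyl)amino on the carbonyl carbon gives an at least 11-fold lower number from compound 2 to compound 3 (1.04 log units; beyond the scatter). The group on this carbonyl carbon therefore has a large effect on the read-out, even though the two groups have the same heavy-atom, hydrogen-bond donor and net charge counts. The step gives only a minimum size, not an exact one: the limit of < 0.25 h in this assay, at which 2 of the 3 values shown sit.

The compounds shown do not separate the contribution of the 1H-indol-2-yl ring from that of losing the amino nitrogen on the carbonyl carbon. As far as these compounds go, it also remains open whether a plain benzylamino group, a phenylamino group or a shorter alkylamino chain on this carbonyl carbon would stay close to compound 2 at 2.8 h.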